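The source may hold more compounds than are shown below. What is called first, only, known or untested is meant among the compounds shown, and "the series" means these compounds.

The compounds measured so far:

Compound 1 `Cc1ccc(/C=C2\CCC/C(=C\c3ccc([N+](=O)[O-])cc3)C2=O)cc1` — in a functional assay on MOLT-4 cells (Homo sapiens) for cytotoxicity, with a stated time of 72 h (a higher number here means a weaker inhibitor, a lower number a stronger inhibitor), compound 1 gives 8440 nM.
Compound 2 `O=C1/C(=C/c2ccc(F)cc2)CCC/C1=C\c1ccc([N+](=O)[O-])cc1` — in this assay compound 2 gives 17100 nM.
Compound 3 `CN(C)c1ccc(/C=C2\CCC/C(=C\c3ccc([N+](=O)[O-])cc3)C2=O)cc1` — in this assay compound 3 gives > 500000 nM, which is a limit of the assay and not a number.

Compound 3 thus stands at the far upper edge of what has been measured: its entry is the limit (the limit of > 500000 nM in this assay, at which 1 of the 3 values shown sits), so only a lower bound is known for it. Compound 4 `O=C1/C(=C/c2ccccc2)CCC/C1=C\c1ccc([N+](=O)[O-])cc1` differs from compound 3 in one place, (hydrogen in place of dimethylamino on an aromatic carbon). The measured steps that bear on this change run in the opposite direction, toward the dimethylamino group: an at least 59-fold higher number from compound 1 to compound 3 (1.77 log units; beyond the scatter), and an at least 29-fold higher number from compound 2 to compound 3 (1.46 log units; beyond the scatter). Both are large, and both end at the same limit. Removing the dimethylamino group is therefore expected to undo much of that movement in this assay, bringing compound 4 back toward the region occupied by compound 1 and compound 2, with a modest uncertainty about whether the unsubstituted ring falls nearer the methyl or the fluoro analogue. Compound 4 is estimated at 15000 nM, within a range of 5000 nM to 60000 nM. This estimate means a step of an at least 33-fold lower number from compound 3 to compound 4 (1.52 log units; beyond the scatter).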

Compound 4, half-maximal inhibitory concentration: 8350 nM
Beside the measured number, compound 4's estimate is 1.8-fold (0.25 log units) above it; measured number inside the range.
By their numbers in this assay, from the lowest: compounds 4 and 1 (each within the scatter of the next); then compound 2. At a limit, above all of these: compound 3.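

At this position, the dimethylamino group is what separates the series from the unsubstituted phenyl in this assay, with an at least 59-fold lower number from compound 3 to compound 4 (1.77 log units; beyond the scatter), so the earlier gap to methyl and fluoro now has a reference compound carrying only hydrogen. Against that reference, methyl and hydrogen cannot be told apart, with a 1.0-fold lower number from compound 1 to compound 4 (0.00 log units; within the scatter), whereas the fluoro compound stands modestly apart, with a 2.0-fold lower number from compound 2 to compound 4 (0.31 log units; beyond the scatter), so of the three smaller groups only fluoro gives a step beyond the scatter from hydrogen. The entry of compound 3 is a limit of the assay and not a number, so the full size of the step to hydrogen stays unknown: the limit of > 500000 nM in this assay, at which 1 of the 4 values shown sits.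

The compounds shown leave open whether the large step belongs to dimethylamino alone or would also appear with a primary amine, a methoxy group or a hydroxyl group in the same place. They also leave open how much the numbers depend on the nitro group, which all four compounds share, and whether a nitrile or a carboxylic acid in its place would keep the same order.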